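The source may report more compounds than this note shows. Statements on the series, on what has been measured and on what is new or still open speak of the compounds shown alone.

Within the data shown here, in a functional assay on MCF7 cells (Homo sapiens) for inhibition, read by MTT assay, with a stated time of 3 days (a higher number here means a weaker inhibitor, a lower number a stronger inhibitor), compound 1 `COc1ccc(COc2cc(/C=C\c3cc(OC)c(OC)c(OC)c3)ccc2OC)cc1` gives 48000 nM, the higher of the two numbers measured so far. Compound 2 `COc1ccccc1/C=C/CCCOc1cc(/C=C\c2cc(OC)c(OC)c(OC)c2)ccc1OC` gives 21000 nM. Still to be measured is compound 3 `COc1ccc(/C=C/CCCOc2cc(/C=C\c3cc(OC)c(OC)c(OC)c3)ccc2OC)cc1`, which departs from compound 1 as follows: 4-(4-methoxyphenyl)but-3-en-1-yl in place of 4-methoxyphenyl on a saturated chain carbon bound to an oxygen on an aromatic ring. The exchange takes place on a saturated chain carbon bound to an oxygen on an aromatic ring, and the rest of compound 1 stays the same. Among the measured compounds shown here, one measured step bears on it: a 2.3-fold lower number from compound 1 to compound 2 (0.36 log units; beyond the scatter). That step is modest but beyond the scatter. The group it brings in, 4-(2-methoxyphenyl)but-3-en-1-yl, differs from the 4-(4-methoxyphenyl)but-3-en-1-yl of compound 3 only in the number in its name. The data do not yet show what that difference does, and a single step is thin support. A similarly modest move towards a lower number in this assay is therefore expected, although a result within the scatter of compound 1 would be no surprise. For compound 3 the estimated value is 22000 nM, with an expected range of 8000 nM to 55000 nM. The estimate means this expected step: a 2.2-fold lower number from compound 1 to compound 3 (0.34 log units; beyond the scatter).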

Compound 3, half-maximal inhibitory concentration: 16000 nM
The estimate for compound 3 lay 1.4-fold (0.14 log units) above the measured number; low and high end bracket the measured number.
By their numbers in this assay, from the lowest: compounds 3 and 2 (each within the scatter of the next); then compound 1.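

In this assay, putting 4-(4-methoxyphenyl)but-3-en-1-yl in place of 4-methoxyphenyl on the saturated chain carbon bound to an oxygen on an aromatic ring gives a 3.0-fold lower number from compound 1 to compound 3 (0.48 log units; beyond the scatter), so the lower number seen with compound 2 no longer rests on a single example of this type of chain. The new comparison of 4-methoxyphenyl with 2-methoxyphenyl, on a double-bonded chain carbon bound to a double-bonded chain carbon, gives a 1.3-fold lower number from compound 2 to compound 3 (0.12 log units; within the scatter), which shows no separation between these two groups in this assay. No independent measurement is available to explain either step.

The compounds shown leave open whether a saturated butyl chain ending in 4-methoxyphenyl would give a number like that of compound 3, as the added chain length and the double bond enter together in the step from compound 1. They also leave open what a hydroxyl group or an amine in place of the methoxy group of 4-methoxyphenyl, or a longer chain at this position, would do to the number.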